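Trimming the Bicyclic Ring to a Chloropyridine

This account rests on a few compounds, and the source may have more. Where it says the series, first, only, none or still open, it means among the compounds named here.

Compound 1 `CC(C)(C)Sc1c(CC(C)(C)C(=O)O)n(Cc2ccc(Cl)cc2)c2ccc(OCc3ccc4cc(F)ccc4n3)cc12` is the starting point. In a functional assay (blood) for inhibition, with Homo sapiens as the target (a lower number here means a stronger inhibitor, a higher number a weaker inhibitor), compound 1 gives 880 nM, at the low end of the two plain numbers, though the step of a 1.1-fold higher number from compound 1 to compound 2 (0.05 log units; within the scatter) sits within the scatter. Compound 2 `CC(C)(C)Sc1c(CC(C)(C)C(=O)O)n(Cc2ccc(Cl)cc2)c2ccc(OCc3ccc4cnccc4n3)cc12` gives 980 nM. Compound 3 `CC(C)(C)Sc1c(CC(C)(C)C(=O)O)n(Cc2ccc(Cl)cc2)c2ccc(OCc3cccnc3)cc12` reaches only a limit of the assay (the limit of > 3000 nM in this assay, at which 1 of the 3 values shown sits), reported for compound 3 as > 3000 nM.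

Compound 4 `CC(C)(C)Sc1c(CC(C)(C)C(=O)O)n(Cc2ccc(Cl)cc2)c2ccc(OCc3cccc(Cl)n3)cc12` differs from compound 1 by 6-chloropyridin-2-yl in place of 6-fluoroquinolin-2-yl on a saturated chain carbon bound to an oxygen on an aromatic ring. The nearest precedents for cutting the group to a single ring are the steps of an at least 3.4-fold higher number from compound 1 to compound 3 (0.53 log units; beyond the scatter) and an at least 3.0-fold higher number from compound 2 to compound 3 (0.48 log units; beyond the scatter), both beyond the scatter toward weaker inhibition. Compound 4 is therefore expected to give about 2500 nM, between 1000 nM and 6000 nM. The expected step is a 2.8-fold higher number from compound 1 to compound 4 (0.45 log units; beyond the scatter).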

Compound 4, half-maximal inhibitory concentration: 410 nM
The estimate for compound 4 lay 6.1-fold (0.79 log units) above the measured number; the whole stated range lies above it.
By their numbers in this assay, from the lowest: compound 4; then compounds 1 and 2 (each within the scatter of the next). At a limit, above all of these: compound 3.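

A single ring can replace the two-ring groups at this place without a loss in this assay, since 6-chloropyridin-2-yl gives a 2.1-fold lower number from compound 1 to compound 4 (0.33 log units; beyond the scatter) and a 2.4-fold lower number from compound 2 to compound 4 (0.38 log units; beyond the scatter). Compound 3 has only a limit of the assay as its value. Not every single ring behaves alike, as pyridin-3-yl goes against this result, with an at least 7.3-fold lower number from compound 3 to compound 4 (0.86 log units; beyond the scatter).

That last step moves the ring's point of attachment and adds the chlorine together, leaving open which of the two matters. On these data alone, how a plain pyridin-2-yl or a 6-methoxypyridin-2-yl would compare also stays open.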